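Ester-to-amide change on the shared core

The source may report more compounds than this note shows. Statements on the series, on what has been measured and on what is new or still open speak of the compounds shown alone.

Compound 1 `CCOC(=O)C1=Cc2ccc(OC)cc2OC1c1cc(OC)c(OC)c(OC)c1`: 25000 nM
Compound 2 `COc1ccc2c(c1)OC(c1cc(OC)c(OC)c(OC)c1)C(C(=O)NC(C)C)=C2`: a limit of the assay, > 50000 nM
Compound 3 `COc1ccc2c(c1)OC(c1cc(OC)c(OC)c(OC)c1)C(C(=O)OC(C)(C)C)=C2`: 14100 nM

In a functional assay for inhibition of nuclear factor NF-kappa-B complex (Homo sapiens) (on this read-out lower numbers stand for stronger inhibition and higher numbers for weaker inhibition), compound 3 gives the lower of the two numbers shown, but its nearest neighbour is compound 1 and the step of a 1.8-fold lower number from compound 1 to compound 3 (0.25 log units; within the scatter) lies within the scatter, so the two cannot be separated. Compound 2 reaches only (the limit of > 50000 nM in this assay, at which 1 of the 3 values shown sits).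

Compound 4 `COc1ccc2c(c1)OC(c1cc(OC)c(OC)c(OC)c1)C(C(=O)N(C)C)=C2` differs from compound 3 in one place: dimethylamino in place of tert-butoxy on a carbonyl carbon. Going by the values given here, two measured steps bear on this exchange of an ester for an amide on the carbonyl carbon. an at least 2.0-fold higher number from compound 1 to compound 2 (0.30 log units; that floor lies within the scatter). an at least 3.5-fold lower number from compound 2 to compound 3 (0.54 log units; beyond the scatter). Both point the same way: the amide carries the higher number, the ester the lower. The amide in compound 4 is dimethylamino rather than isopropylamino, so the size of the step is uncertain, yet a move toward a higher number beyond the scatter is expected, a 3.5-fold higher number from compound 3 to compound 4 (0.55 log units; beyond the scatter). For compound 4 the estimated value is 50000 nM, with a range from 15000 nM to 150000 nM, and a limit rather than a number is a real possibility.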

Compound 4, half-maximal inhibitory concentration: > 50000 nM
Compound 4 ended at the assay's limit; the forecaster's own chance of this, stated with the estimate: 50%; the middle value lies on the limit itself.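

At the carbonyl carbon in this assay, the exchange of tert-butoxy for dimethylamino gives an at least 3.5-fold higher number from compound 3 to compound 4 (0.54 log units; beyond the scatter), while the exchange of ethoxy for dimethylamino gives an at least 2.0-fold higher number from compound 1 to compound 4 (0.30 log units; that floor lies within the scatter), so the penalty seen with the first amide also appears with a second, differently substituted one. The amide hydrogen of compound 2 is absent from compound 4, so the presence of that hydrogen does not separate the amides shown from the esters shown. The step between the two amides cannot be read, and any ranking of isopropylamino against dimethylamino stays closed because both compounds end at the same limit: the limit of > 50000 nM in this assay, at which 2 of the 4 values shown sit.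

Going by these compounds, whether any amide at this carbonyl carbon can give a number inside the range of the assay stays open, and a primary amide, a morpholine amide or the free carboxylic acid would bear on that. Compound 1 and compound 3 lie within the scatter of each other, so the ester side gives no direction yet, and a benzyl ester or a longer chain on the ester oxygen could test it.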